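A few compounds are considered here, and "the series" means these few. Any claim that something is new, unique, unknown or untested is made for them only; others in the source may bear on it.

In a functional assay on A549 cells (Homo sapiens) for cytotoxicity, read by MTT assay (a higher number here means a weaker inhibitor, a lower number a stronger inhibitor), compound 3 `C=C1C(=O)[C@]23C[C@@]1(OCC)CC[C@H]2[C@@]12C=CC(=O)[C@](C)(C(=O)O1)[C@H]2[C@@H]3C(=O)OC` gives 18200 nM. Compound 1 `C=C1C(=O)[C@]23C[C@@]1(O)CC[C@H]2[C@@]12C=CC(=O)[C@](C)(C(=O)O1)[C@H]2[C@@H]3C(=O)OCc1ccccc1` gives 23900 nM, which lies within the usual scatter of the number for compound 3, so these two cannot be ranked. Compound 2 `C=C1C(=O)[C@]23C[C@@]1(I)CC[C@H]2[C@@]12C=CC(=O)[C@](C)(C(=O)O1)[C@H]2[C@@H]3C(=O)OCc1ccccc1` gives 46000 nM, a higher number than that of compound 3 and one beyond the scatter.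

Compound 4 `C=C1C(=O)[C@]23C[C@@]1(OCC)CC[C@H]2[C@@]12C=CC(=O)[C@](C)(C(=O)O1)[C@H]2[C@@H]3C(=O)OCc1ccccc1` has not yet been measured. It differs from compound 3 in one place: phenyl in place of hydrogen on a saturated chain carbon bound to an oxygen next to a carbonyl group. Read one bond further out, this turns methoxycarbonyl into benzyloxycarbonyl.

Among the compounds with values here, no measured step makes this change on its own. Within the data shown here, the only step available, a 1.9-fold higher number from compound 1 to compound 2 (0.28 log units; within the scatter), puts iodo in place of hydroxy on a saturated ring carbon, which is a different place, so it says little about this change. It does show a modest response to a change elsewhere in the molecule. Compound 1 carries benzyloxycarbonyl and still gives 23900 nM, close to compound 3, but it also differs from compound 3 in a second place, so this is only a weak hint.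

No step beyond the scatter is therefore expected in this assay, and the expected step, a 1.1-fold higher number from compound 3 to compound 4 (0.04 log units; within the scatter), has no firm direction. For compound 4 the estimated value is 20000 nM, with an expected range of 10000 nM to 42000 nM.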

Compound 4, half-maximal inhibitory concentration: 24200 nM
The estimate for compound 4 lay 1.2-fold (0.08 log units) below the measured number; measured number inside the range.
By their numbers in this assay, from the lowest: compounds 3, 1, 4 and 2 (each within the scatter of the next, the first and the last beyond it).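

In this assay, within the data shown here, the swap of methoxycarbonyl for benzyloxycarbonyl gives a 1.3-fold higher number from compound 3 to compound 4 (0.12 log units; within the scatter) and is the first direct reading of this change, showing that adding a phenyl on this saturated chain carbon bound to an oxygen next to a carbonyl group does not move the number beyond what repeat measurements would scatter by. With benzyloxycarbonyl held in place, the result also gives two new readings at the saturated ring carbon: ethyl in place of hydrogen on the oxygen gives a 1.0-fold higher number from compound 1 to compound 4 (0.01 log units; within the scatter) and ethoxy in place of iodo gives a 1.9-fold lower number from compound 2 to compound 4 (0.28 log units; within the scatter), so neither change separates the compounds in this assay. No measurement is available that could explain these small steps.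

The compounds shown carry only hydrogen or phenyl on this chain carbon, so it remains open whether an amine, a carboxylic acid or a longer chain there would produce a step beyond the scatter. Going by these compounds, it is also open whether the small size of the phenyl step would hold with hydroxy or iodo on the ring carbon in place of ethoxy.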